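Carbonyl aryl exchange on the shared core: toward compound 3

This account rests on a few compounds, and the source may have more. Where it says the series, first, only, none or still open, it means among the compounds named here.

Two members of the series have been run in a functional assay on HeLa cells (Homo sapiens) for cytotoxicity, read by MTT assay, with a stated time of 24 h; on this read-out higher numbers stand for weaker inhibition and lower numbers for stronger inhibition. Compound 1 `O=C(NC(=S)Nc1nc2cc([N+](=O)[O-])ccc2s1)c1ccccc1` gives 75100 nM. Compound 2 `O=C(NC(=S)Nc1nc2cc([N+](=O)[O-])ccc2s1)c1cccs1` gives 72600 nM. Within the data shown here, the one measured step, a 1.0-fold lower number from compound 1 to compound 2 (0.01 log units; within the scatter), involves thiophen-2-yl in place of phenyl on a carbonyl carbon. Compound 2 sits at one end of the two numbers, with compound 1 within the scatter of it, so no order between the two is claimed.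

Compound 3 `O=C(NC(=S)Nc1nc2cc([N+](=O)[O-])ccc2s1)c1ccc([N+](=O)[O-])cc1` is not yet measured. It differs from compound 2 by 4-nitrophenyl in place of thiophen-2-yl on a carbonyl carbon. Among the measured compounds shown here, the only step bearing on the aryl group on the carbonyl carbon is a 1.0-fold lower number from compound 1 to compound 2 (0.01 log units; within the scatter), which stayed within the scatter; no measured step shows what a 4-nitrophenyl does on this carbonyl carbon. In this assay, for the measured compounds named here, the expected step is therefore about a 1.0-fold lower number from compound 2 to compound 3 (0.02 log units; within the scatter), none beyond the scatter, with wide uncertainty because only the single step of a 1.0-fold lower number from compound 1 to compound 2 (0.01 log units; within the scatter) is available. Compound 3 is accordingly estimated at 70000 nM, with a range from 25000 nM to 200000 nM.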

Compound 3, half-maximal inhibitory concentration: 68500 nM
Estimate against measurement, compound 3: 1.0-fold (0.01 log units) above; the measured number falls inside the stated range.
By their numbers in this assay, from the lowest: compounds 3, 2 and 1 (each within the scatter of the next).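

In this assay the carbonyl carbon now carries three aryl groups, and a 1.1-fold lower number from compound 2 to compound 3 (0.03 log units; within the scatter) stays within the scatter even though a six-membered aromatic ring of carbon only with a nitro group replaces a five-membered aromatic ring with a hetero atom. The second new step, nitro in place of hydrogen on an aromatic carbon, gives a 1.1-fold lower number from compound 1 to compound 3 (0.04 log units; within the scatter) and also stays within the scatter, so this substitution on the phenyl group of compound 1 produces no readable change, and no order among the three compounds can be claimed. Nothing available accounts for how closely these numbers sit together.

Open, as far as these compounds go, is whether a non-aromatic group on the carbonyl carbon, such as cyclohexyl or a longer alkyl chain, or an aryl group carrying an amine or a carboxylic acid, would give a step beyond the scatter. From the compounds shown here alone, all three compounds share the same core, so what a change elsewhere on that core would do to this cytotoxicity reading also remains open.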